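A few compounds are considered here, and "the series" means these few. Any claim that something is new, unique, unknown or untested is made for them only; others in the source may bear on it.

In a functional assay on MCF7 cells (Homo sapiens) for cytotoxicity, read by MTT assay, with a stated time of 72 h (on this read-out lower numbers stand for stronger inhibition and higher numbers for weaker inhibition), compound 2 `O=C(Nc1ccc(Oc2ccnc3[nH]ccc23)c(F)c1)c1cc(-c2ccc(C(F)(F)F)cc2)ncn1` gives 2840 nM, the higher of the two numbers recorded so far; its nearest neighbour, compound 1 `Cc1ccc(-c2cc(C(=O)Nc3ccc(Oc4ccnc5[nH]ccc45)cc3)ncn2)cc1`, gives 1620 nM, and the two values sit within the scatter of each other. Compound 3 `Cc1ccc(-c2cc(C(=O)Nc3ccc(Oc4ccnc5[nH]ccc45)c(F)c3)ncn2)cc1` differs from compound 2 by methyl in place of trifluoromethyl on an aromatic carbon. Among the compounds with values here, no measured pair shows this change alone. Because compound 1 carries the same methyl group and gives 1620 nM, compound 3 is expected to give about 1900 nM in this assay, between 800 nM and 4500 nM. The expected step of a 1.5-fold lower number from compound 2 to compound 3 (0.17 log units; within the scatter) is thus small, hardly beyond the scatter.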

Compound 3, half-maximal inhibitory concentration: 6730 nM
Beside the measured number, compound 3's estimate is 3.5-fold (0.55 log units) below it; the whole stated range lies below it.
By their numbers in this assay, from the lowest: compounds 1 and 2 (each within the scatter of the next); then compound 3.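

In this assay, within the data shown here, the single changes can now be read apart: with the fluoro kept, methyl in place of trifluoromethyl gives a 2.4-fold higher number from compound 2 to compound 3 (0.37 log units; beyond the scatter), so the group on this carbon, para to a large group, does affect the number. With methyl kept, fluoro in place of hydrogen on an aromatic carbon gives a 4.2-fold higher number from compound 1 to compound 3 (0.62 log units; beyond the scatter), so the effect of methyl here cannot be judged without regard to the fluoro. The compounds shown leave open how a methoxy group or an amine would read on this carbon, and whether the fluoro step holds with trifluoromethyl present. Nothing available here explains either step.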